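Three weak quinazoline-ether analogues and a shifted nitroimidazole

The source may report more compounds than this note shows. Statements on the series, on what has been measured and on what is new or still open speak of the compounds shown alone.

Compound 1 `COc1cc2ncnc(Nc3ccc(F)c(Cl)c3)c2cc1OCCn1ccnc1[N+](=O)[O-]` was tested in a functional assay on HT-29 cells (Homo sapiens) for cytotoxicity, read by sulforhodamine B assay, with a stated time of 72 h (a lower number here means a stronger inhibitor, a higher number a weaker inhibitor), where compound 1 gives 10000 nM. Among the three measured numbers this is the second highest, but neither neighbour stands apart from it: compound 2 `C#Cc1cccc(Nc2ncnc3cc(OC)c(OCCCn4ccnc4[N+](=O)[O-])cc23)c1` gives 5530 nM, a gap that falls within the scatter of the method, and compound 3 `COc1cc2ncnc(Nc3ccc(OCc4cccc(F)c4)c(Cl)c3)c2cc1OCCCn1ccnc1[N+](=O)[O-]` gives 20000 nM, again within the scatter. The three compounds therefore read as equally weak in this assay, with no ordering among them that the numbers would support.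

Compound 4 `COc1cc2ncnc(Nc3ccc(F)c(Cl)c3)c2cc1OCCCn1c([N+](=O)[O-])cnc1C` has not yet been measured. It differs from compound 1 in one place: (2-methyl-5-nitro-1H-imidazol-1-yl)methyl in place of 2-nitro-1H-imidazol-1-yl on a saturated chain carbon, two bonds along the chain from an oxygen on an aromatic ring. For the measured compounds named here, no pair of measured compounds isolates this change, so there is no measured step to lean on; the only guidance is that all three measured compounds sit in the same weak band regardless of the length of the chain or the substitution of the aromatic amine.

On that basis compound 4 is expected to stay in the same band, with a step from compound 1 to compound 4 of no change at the digits printed from compound 1 to compound 4 (within the scatter), which is no step beyond the scatter. The estimate for compound 4 in this assay is 10000 nM, with a range from 4000 nM to 25000 nM.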

Compound 4, half-maximal inhibitory concentration: 11500 nM
Compound 4: the middle estimate sits 1.2-fold (0.06 log units) below what was measured; measured number inside the range.
By their numbers in this assay, from the lowest: compounds 2, 1, 4 and 3 (each within the scatter of the next, the first and the last beyond it).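

In this assay, putting (2-methyl-5-nitro-1H-imidazol-1-yl)methyl in place of 2-nitro-1H-imidazol-1-yl, on a saturated chain carbon, two bonds along the chain from an oxygen on an aromatic ring, gives a 1.2-fold higher number from compound 1 to compound 4 (0.06 log units; within the scatter). For the compounds shown here, the earlier compounds shared one band but differed from each other in more than one place, whereas this is the first measured one-place step, and it shows that this exchange, with its larger group, leaves the number within the scatter on the core of compound 1. Going by these compounds alone, no accompanying evidence bears on this result, and the single step cannot divide the exchange into its separate parts, the added methyl, the moved nitro group and the extra chain carbon.

What the compounds shown leave open is whether the nitroimidazole matters at this place at all, since a morpholine, a carboxylic acid or a plain imidazole without a nitro group could be compared there only with further data. As far as these compounds go, it also remains open whether the same exchange would stay within the scatter with a different aromatic amine on the shared core.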